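Indolyl azobenzamides against P388 cells: an anilide substitution

The source may hold more compounds than are shown below. What is called first, only, known or untested is meant among the compounds shown, and "the series" means these compounds.

Measured compounds:
- compound 1 `O=C(Nc1ccccc1)c1ccc(/N=N\c2c[nH]c3ccccc23)cc1`: "not active" (no number reported)
- compound 2 `Cc1ccc(NC(=O)c2ccc(/N=N\c3c[nH]c4ccccc34)cc2)c(C)c1`: 190000 nM

In a functional assay on P388 cells (Mus musculus) for inhibition, read by MTT assay, with a stated time of 72 h (a higher number here means a weaker inhibitor, a lower number a stronger inhibitor), compound 2 gives 190000 nM. Compound 1, the plain anilide, gives "not active" (no number reported) in this assay; no number accompanies that entry. Among the compounds with values here, compound 2 is therefore the only compound of the pair with a measured value, and that value is weak. Whether compound 1 and compound 2 differ beyond the scatter cannot be read from these two entries.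

Compound 3 `COc1ccccc1NC(=O)c1ccc(/N=N\c2c[nH]c3ccccc23)cc1` has not yet been measured in this assay. It differs from compound 2 by 2-methoxyphenyl in place of 2,4-dimethylphenyl on an amide-type nitrogen. Within the data shown here, the only comparison available is the weak value of compound 2 and the inactive entry for compound 1, so no step between measured compounds can guide the expectation. Given that compound 2 gives 190000 nM and compound 1 gives "not active" (no number reported), compound 3 is expected to sit at or beyond the weak end, with a fair chance that this assay returns no number at all. For compound 3 the estimate is 260000 nM, within 100000 nM to 700000 nM. The expected step is a 1.4-fold higher number from compound 2 to compound 3 (0.14 log units; within the scatter), a loss that may or may not exceed the scatter.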

Compound 3, half-maximal inhibitory concentration: "not active" (no number reported)
Compound 3 has no reported number here, so the estimate cannot be set against anything.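

In this assay, within the data shown here, compound 3 gives "not active" (no number reported) and so, like compound 1, carries no number; no step from compound 2 to either can be read. The compounds shown leave open whether any anilide substitution on the shared core gives activity stronger than compound 2 at 190000 nM in this series. No measured evidence bears on this result.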